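The source may hold more compounds than are shown below. What is called first, only, known or untested is meant among the compounds shown, and "the series" means these compounds.

Compound 3 `C[C@@H](O[C@@H]1CN(C(=O)N(C)C)C[C@H]1c1ccc(F)cc1)c1cc(C(F)(F)F)cc(C(F)(F)F)c1` is the weakest-looking of three measured compounds in an assay on CHO cells for displacement of a labelled ligand from Substance-P receptor (Homo sapiens) (on this read-out higher numbers stand for weaker inhibition and lower numbers for stronger inhibition), where compound 3 gives 0.38 nM. Compound 1 `C[C@@H](O[C@@H]1CN(C=O)C[C@H]1c1ccc(F)cc1)c1cc(C(F)(F)F)cc(C(F)(F)F)c1` gives 0.24 nM, and compound 2 `CC(C)C(=O)N1C[C@@H](O[C@H](C)c2cc(C(F)(F)F)cc(C(F)(F)F)c2)[C@H](c2ccc(F)cc2)C1` gives 0.15 nM. The step of a 1.6-fold higher number from compound 1 to compound 3 (0.20 log units; within the scatter) lies within the scatter, while a 2.5-fold higher number from compound 2 to compound 3 (0.40 log units; beyond the scatter) is a modest shift beyond it. Compound 4 `CC(C)NC(=O)N1C[C@@H](O[C@H](C)c2cc(C(F)(F)F)cc(C(F)(F)F)c2)[C@H](c2ccc(F)cc2)C1` differs from compound 3 by isopropylamino in place of dimethylamino on a carbonyl carbon. Both measured steps bearing on this position, a 1.6-fold lower number from compound 1 to compound 2 (0.20 log units; within the scatter) and a 2.5-fold higher number from compound 2 to compound 3 (0.40 log units; beyond the scatter), were small, so exchanging one group on this carbonyl carbon for another has moved the numbers little so far. The expected step of a 1.3-fold lower number from compound 3 to compound 4 (0.10 log units; within the scatter) is therefore small, at most a slight decrease. Compound 4 is estimated at 0.3 nM, with a range from 0.12 nM to 0.8 nM.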

Compound 4, half-maximal inhibitory concentration: 0.06 nM
Estimate against measurement, compound 4: 5.0-fold (0.70 log units) above; the measured number lies below the stated range.
By their numbers in this assay, from the lowest: compound 4; then compounds 2, 1 and 3 (each within the scatter of the next, the first and the last beyond it).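

Groups on this carbonyl carbon are not as interchangeable as the earlier compounds suggested: in this assay, exchanging dimethylamino for isopropylamino gives a 6.3-fold lower number from compound 3 to compound 4 (0.80 log units; beyond the scatter). The change also goes beyond the scatter against the other two groups, with a 2.5-fold lower number from compound 2 to compound 4 (0.40 log units; beyond the scatter) and a 4.0-fold lower number from compound 1 to compound 4 (0.60 log units; beyond the scatter), which leaves compound 4 with the lowest number of the four. Nothing measured here explains this shift.

Still open, going by these compounds, is whether the trend holds for other amino groups on this carbonyl carbon, such as methylamino or tert-butylamino. A cyclic amine such as pyrrolidine, which has no hydrogen on its nitrogen once attached here, is equally untested by these compounds.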